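The compounds below may be only part of what the source reports. "The series", "measured", "known", "first", "only" and "open" are said of these compounds alone.

Of the compounds shown here, two have so far been measured in a functional assay on UO-31 cells (Homo sapiens) for antiproliferative activity, read by sulforhodamine B assay, with a stated time of 48 h; on this read-out lower numbers stand for stronger inhibition of growth and higher numbers for weaker inhibition of growth. Compound 1 `COc1ccc(OC)c(/C=C/c2nnc(Nc3ccc(Cl)cc3)o2)c1` gives 3130 nM there, and compound 2 `COc1ccc(OC)c(/C=C/C(=O)N/N=C/c2ccc(Cl)cc2)c1` gives 3370 nM. Compound 2 carries the higher of the two numbers, yet its nearest neighbour, compound 1, sits within the usual scatter, so the two cannot be ranked against each other in this assay. The step under consideration leads from compound 2 to compound 3 `COc1ccc(OC)c(/C=C/C(=O)N/N=C/c2ccccc2)c1`, which has yet to be tested in this assay. The change is hydrogen in place of chloro on an aromatic carbon. Among the measured compounds shown here, no measured pair in this set shows what such a change does, so there is no direct guide for its size or direction. The expected step is a 1.3-fold higher number from compound 2 to compound 3 (0.13 log units; within the scatter), a small one, if anything toward weaker inhibition of growth, and not clearly beyond the scatter. In this assay compound 3 is estimated at 4500 nM, with a range from 1500 nM to 13000 nM.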

Compound 3, concentration for 50% growth inhibition: 5900 nM
Compound 3: middle estimate off by 1.3-fold (0.12 log units), on the low side; low and high end bracket the measured number.
By their numbers in this assay, from the lowest: compounds 1, 2 and 3 (each within the scatter of the next).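

Among the compounds shown here, this is the first measured pair for the change from 4-chlorophenyl to phenyl, and in this assay it gives a 1.8-fold higher number from compound 2 to compound 3 (0.24 log units; within the scatter). In this pair, then, hydrogen can stand in place of chloro on the aromatic carbon para to a large group without a step that clears the usual scatter, so compound 2 and compound 3 cannot be ranked against each other. Nothing at hand gives a reason for the size of this step.

Going by these compounds, it stays open whether another group at this place, such as an amine, a methoxy group or a carboxylic acid, would give a step beyond the scatter. On these data alone, it also stays open whether the same change from 4-chlorophenyl to phenyl on the core of compound 1 would read alike in this assay.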